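From methoxy to isopropoxy on the shared core

The source may hold more compounds than are shown below. What is called first, only, known or untested is meant among the compounds shown, and "the series" means these compounds.

Compound 1 `CCOC(=O)c1cnc(-c2ccccc2N)[nH]c1=O`: "not determined" (no result reported)
Compound 2 `CCOC(=O)c1cnc(-c2ccccc2OC)[nH]c1=O`: 10 mg/kg

In a functional assay on the whole organism (strain Sprague-Dawley) for inhibition, with Rattus norvegicus as the target, with a stated time of 10 min (a lower number here means that less compound is needed, a higher number that more compound is needed for the effect), compound 2 gives 10 mg/kg. Within the data shown here, this is the single number available, and compound 1 has no result to set against it, so compound 2 cannot yet be ranked. Compound 3 `CCOC(=O)c1cnc(-c2ccccc2OC(C)C)[nH]c1=O` keeps the shared core and carries isopropyl in place of methyl on an oxygen on an aromatic ring. The same difference reads methoxy to isopropoxy. Among the measured compounds shown here, no step between measured compounds exists to size this change, and the forecast stays loose. A modest shift towards a lower dose is expected, though a result within the scatter would be no surprise. The expected change is a 2.0-fold lower number from compound 2 to compound 3 (0.30 log units; within the scatter). For compound 3 the estimated dose is 5 mg/kg, with an expected range from 1.5 mg/kg to 20 mg/kg.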

Compound 3, dose for 50% inhibition: 2 mg/kg
Beside the measured number, compound 3's estimate is 2.5-fold (0.40 log units) above it; low and high end bracket the measured number.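

In this assay, replacing methyl with isopropyl on an oxygen on an aromatic ring gives a 5.0-fold lower number from compound 2 to compound 3 (0.70 log units; beyond the scatter), which lies beyond the usual scatter. The earlier compounds shown here offered a single number and no comparison, whereas this pair gives a first measured step and shows that the dose responds to the group carried on this oxygen. No measurement shown bears on why the dose moves.

With compound 1 lacking a number, any step involving it cannot be read, so this single step from methyl to isopropyl is all that describes the position and sets no trend. As far as these compounds go, whether a longer chain such as butyl or a ring such as cyclopentyl on the same oxygen would lower the dose further, or raise it, remains open.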